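A few compounds are considered here, and "the series" means these few. Any claim that something is new, unique, unknown or untested is made for them only; others in the source may bear on it.

Measured so far:
compound 1, `Nc1scc(CN2CCN(c3cc(Cl)cc(Cl)c3)CC2)c1C(=O)c1ccc(Cl)cc1`: -1%
compound 2, `Nc1scc(CN2CCN(c3ccccc3C(F)(F)F)CC2)c1C(=O)c1ccc(Cl)cc1`: 0%
compound 3, `Nc1scc(CN2CCN(c3ccc(F)cc3F)CC2)c1C(=O)c1ccc(Cl)cc1`: 0%

In a functional assay on CHO cells with adenosine receptor A1 (Homo sapiens) as the target, read by cAMP accumulation and immunoassay, with a stated time of 6 min, tested at 0.01 uM (on this read-out lower numbers stand for a stronger effect and higher numbers for a weaker effect at the one concentration tested), compound 2 gives 0%, the same digits as compound 3, and it differs from compound 1 by a number 1 percentage points higher from compound 1 to compound 2 (within the scatter); all three numbers sit within the scatter of each other and close to no effect at the single concentration.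

Compound 4, `Nc1scc(CN2CCN(CCCc3ccc(Cl)cc3)CC2)c1C(=O)c1ccc(Cl)cc1`, has not yet been measured. It differs from compound 2 in one place: 3-(4-chlorophenyl)propyl in place of 2-(trifluoromethyl)phenyl on an amine nitrogen in a ring. The measured steps of a number 1 percentage points higher from compound 1 to compound 3 (within the scatter) and no change at the digits printed from compound 2 to compound 3 (within the scatter) each exchanged one ring on that nitrogen for another ring and moved nothing beyond the scatter. None of them replaced a ring with a 3-(4-chlorophenyl)propyl chain, so they bear only loosely on this change. Going by the values given here, with every number so far near zero, the expected step of no change at the digits printed from compound 2 to compound 4 (within the scatter) is none beyond the scatter. Compound 4 is therefore estimated at 0%, within -12% to 12%.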

Compound 4, a percentage reported as activity, at one concentration (the size of the read-out at that concentration, not a potency): 0%
Estimate against measurement, compound 4: no gap at the digits printed; the range from low to high includes it.
By their numbers in this assay, from the lowest: compounds 1, 2, 3 and 4 (each within the scatter of the next).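

Compound 4 shows that a 3-(4-chlorophenyl)propyl chain on this ring nitrogen reads the same as the rings carried there before: in this assay the steps are no change at the digits printed from compound 2 to compound 4 (within the scatter) and no change at the digits printed from compound 3 to compound 4 (within the scatter) and a number 1 percentage points higher from compound 1 to compound 4 (within the scatter) as well. All four compounds sit close to no effect at the single concentration, so this read-out separates none of these groups. Nothing available here offers a reason for this flat result.

Still open, as far as these compounds go, is whether an amine or a carboxylic acid on that chain would move the number. Also open, from the compounds shown here alone, is how these compounds compare at other concentrations.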